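The compounds below may be only part of what the source reports. "The series", "measured", "known", "first", "only" and "open" are said of these compounds alone.

Among the compounds with values here, compound 2 `CN1CCC(NC(=O)c2ccncc2Nc2cc(-c3ccc4sc(N)nc4c3)c3nccnc3c2)C1` stands at the lowest of the two numbers measured so far. In an assay for inhibition of 6-phosphofructo-2-kinase/fructose-2,6-bisphosphatase 3 (Homo sapiens), read by ADP-Glo, with a stated time of 2 h (on this read-out lower numbers stand for stronger inhibition and higher numbers for weaker inhibition), compound 2 gives 35 nM. Within the data shown here, the only other measured compound, compound 1 `CN1CCC(NC(=O)c2ccncc2Nc2cc(-c3ccc4ccn(C)c4c3)c3nccnc3c2)CC1`, gives in this assay a value of 38 nM, and the two numbers lie within the scatter of each other, so neither can be called the more potent. Compound 3 `CN1CCC(NC(=O)c2ccncc2Nc2cc(-c3cc(F)c4ccn(C)c4c3)c3nccnc3c2)C1` has not yet been measured. It arises from compound 2 by a single change: 4-fluoro-1-methyl-1H-indol-6-yl in place of 2-amino-1,3-benzothiazol-5-yl on an aromatic carbon. Among the measured compounds shown here, no measured pair shows this step, so its size is not known from the data. Compound 1 carries the entering group apart from the fluorine and sits within the scatter of compound 2, which supports an expectation of no step beyond the scatter, no change at the digits printed from compound 2 to compound 3 (within the scatter). Compound 3 is therefore estimated at 35 nM in this assay, with a range from 15 nM to 80 nM.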

Compound 3, half-maximal inhibitory concentration in the 6-phosphofructo-2-kinase/fructose-2,6-bisphosphatase 3 assay: 17 nM
Beside the measured number, compound 3's estimate is 2.1-fold (0.31 log units) above it; measured number inside the range.
By their numbers in the 6-phosphofructo-2-kinase/fructose-2,6-bisphosphatase 3 assay, from the lowest: compound 3; then compounds 2 and 1 (each within the scatter of the next).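

In the 6-phosphofructo-2-kinase/fructose-2,6-bisphosphatase 3 assay, placing 4-fluoro-1-methyl-1H-indol-6-yl in place of 2-amino-1,3-benzothiazol-5-yl on this aromatic carbon gives a 2.1-fold lower number from compound 2 to compound 3 (0.31 log units; beyond the scatter), the first step shown that lies beyond the scatter, so the group held here does bear on the read-out, if modestly. In a physicochemical assay for solubility, read by spectrophotometry, measured as kinetic solubility, at pH 8, tested at 500 uM (on this read-out lower numbers stand for lower solubility and higher numbers for higher solubility), the same change gives a 1.3-fold lower number from compound 2 to compound 3 (0.11 log units; within the scatter), with compound 2 at 241 ug/mL and compound 3 at 185 ug/mL. Nothing available explains the step in inhibition.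

The change alters the ring system, the fluorine, the methyl group and the amino group in one move, so the compounds shown do not tell which of these carries the step. They also leave open how a chlorine or a methoxy group in the place of the fluorine would read.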